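Amide substituent variation in a piperazine acetamide series

This account rests on a few compounds, and the source may have more. Where it says the series, first, only, none or still open, it means among the compounds named here.

Compound 2 `O=C(CN1CCN(c2nnc(Cc3ccncc3)c3ccccc23)CC1)Nc1ccc(Br)cc1` holds the lowest of the two numbers in hand: in a functional assay on A549 cells (Homo sapiens) for cytotoxicity, read by MTT assay, with a stated time of 72 h (a higher number here means a weaker inhibitor, a lower number a stronger inhibitor), compound 2 gives 2710 nM. Among the compounds with values here, compound 1 `O=C(CN1CCN(c2nnc(Cc3ccccc3)c3ccccc23)CC1)Nc1c(F)cccc1F` gives 84500 nM in this assay, a gap beyond the scatter; the two differ in more than one place, so no single step is counted between them. Compound 3 `O=C(CN1CCN(c2nnc(Cc3ccncc3)c3ccccc23)CC1)Nc1ccc(F)c(C(F)(F)F)c1` carries the change (4-fluoro-3-(trifluoromethyl)phenyl in place of 4-bromophenyl on an amide-type nitrogen). Within the data shown here, no measured pair here isolates the group on the amide-type nitrogen, so the direction is open; a step from compound 2 of no more than the scatter is expected, a 1.3-fold higher number from compound 2 to compound 3 (0.11 log units; within the scatter). Compound 3 is therefore expected at 3500 nM, within 1000 nM to 12000 nM.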

Compound 3, half-maximal inhibitory concentration: 16000 nM
Compound 3: the middle estimate sits 4.6-fold (0.66 log units) below what was measured; the whole stated range lies below it.
By their numbers in this assay, from the lowest: compound 2; then compound 3; then compound 1.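

Compound 2 and compound 3 differ only in the group on the amide-type nitrogen, which gives this position its first single-place reading: in this assay the change to 4-fluoro-3-(trifluoromethyl)phenyl from 4-bromophenyl reads as a 5.9-fold higher number from compound 2 to compound 3 (0.77 log units; beyond the scatter) and so shows that the aryl group here affects the number. Nothing at hand explains this step.

The compounds shown do not separate the contribution of the fluorine from that of the trifluoromethyl group. They also leave open how an aminophenyl group, a carboxyphenyl group or a plain alkyl chain on this nitrogen would compare.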